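Swapping an aromatic pyrrole for a saturated pyrrolidine

This account rests on a few compounds, and the source may have more. Where it says the series, first, only, none or still open, it means among the compounds named here.

Measured compounds:
Compound 1, `C[C@@H]1CCCN1c1c(C#N)c2c(N)nc(Nc3ccn(C)n3)cc2n1C`: 13 nM
Compound 2, `Cn1c(-n2cccc2)c(C#N)c2c(N)ncnc21`: 1980 nM
Compound 3, `Cn1c(-c2cccc(F)c2F)c(C#N)c2c(N)ncnc21`: 11 nM

In an assay on isolated protein for binding affinity to Leucine-rich repeat serine/threonine-protein kinase 2 variant G2019S (Homo sapiens), read by TR-FRET and LanthaScreen, with a stated time of 2 h (on this read-out higher numbers stand for weaker inhibition and lower numbers for stronger inhibition), compound 2 gives 1980 nM, the highest of the three numbers. Its nearest neighbour is compound 1 with 13 nM, and compound 3 lies furthest with 11 nM; both gaps are well beyond the usual scatter, so compound 2 is clearly the weakest inhibitor of the set.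

Compound 4, `C[C@@H]1CCCN1c1c(C#N)c2c(N)ncnc2n1C`, has not yet been measured. It differs from compound 2 in one place: 2-methylpyrrolidin-1-yl in place of 1H-pyrrol-1-yl on an aromatic carbon. The same 2-methylpyrrolidin-1-yl group is present in compound 1, which reaches 13 nM, though compound 1 also carries a further substituent that compound 4 lacks, so the two cannot be compared directly. Going by the values given here, no measured pair isolates this change. A large step downward, from the region of compound 2 toward the region of compounds 1 and 3, is nonetheless expected, of size a 20-fold lower number from compound 2 to compound 4 (1.30 log units; beyond the scatter). Compound 4 is therefore expected to give about 100 nM, within the range 20 nM to 600 nM.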

Compound 4, inhibition constant: 0.7 nM
Compound 4: the middle estimate sits 140-fold (2.15 log units) above what was measured, and the stated range ends above it.
By their numbers in this assay, from the lowest: compound 4; then compounds 3 and 1 (each within the scatter of the next); then compound 2.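

Replacing 1H-pyrrol-1-yl with 2-methylpyrrolidin-1-yl on this aromatic carbon gives a 2800-fold lower number from compound 2 to compound 4 (3.45 log units; beyond the scatter) in this assay and is the first pair shown that isolates a change at this position. With the rest of the structure held constant, the group at this position alone moves the number across a wide span. Nothing shown accounts for the size of this step.

The step replaces the aromatic ring with a non-aromatic one and also adds a methyl group and a defined stereocentre, and the compounds shown do not separate these changes. From the compounds shown here alone, it remains open where an unsubstituted pyrrolidin-1-yl group, the opposite stereoisomer of 2-methylpyrrolidin-1-yl or an open-chain dimethylamino group would fall.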